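The compounds below may be only part of what the source reports. "The series", "measured", "known", "first", "only" and "open" are said of these compounds alone.

All three measured compounds were tested in a functional assay on NCI-H460 cells (Homo sapiens) for cytotoxicity, read by MTT assay, with a stated time of 72 h (a higher number here means a weaker inhibitor, a lower number a stronger inhibitor), which gave the following numbers:

compound 1, `CN(C)CCCNc1nc(-c2ccc(NC(=O)Nc3ccccc3Cl)cc2)nc2c(Cl)c(Cl)sc12`: 490 nM
compound 2, `CN(C)CCCNc1nc(-c2ccc(NC(=O)Nc3ccc(Cl)cc3Cl)cc2)nc2c(Cl)c(Cl)sc12`: 980 nM
compound 3, `CN(C)CCNc1nc(-c2ccc(NC(=O)Nc3ccccc3Cl)cc2)nc2ccsc12`: 230 nM

Compound 1 and compound 2 share one core and differ in a single place: chloro in place of hydrogen on an aromatic carbon. In this assay this change gave a 2.0-fold higher number from compound 1 to compound 2 (0.30 log units; within the scatter), a step small enough to fall within the usual scatter of repeated measurements, so the two numbers cannot be ranked against each other.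

Compound 3 sits on a different core. The difference between the two cores is not broken down here. Among the three measured compounds, compound 3 gives the lowest number in this assay, and its gaps to compound 1 and to compound 2 both lie beyond the scatter.

Compound 4, `CN(C)CCNc1nc(-c2ccc(NC(=O)Nc3ccc(Cl)cc3Cl)cc2)nc2ccsc12`, has not yet been measured. It relates to compound 3 exactly as compound 2 relates to compound 1: chloro in place of hydrogen on an aromatic carbon. The surroundings of the change are described in the same words for both pairs, so this is the same change made on a second core.

For the measured compounds named here, the only guide to its effect is the earlier pair, where the change left the number within the scatter. The expected step is therefore a 2.0-fold higher number from compound 3 to compound 4 (0.30 log units; within the scatter). This expectation rests on the measured 2.0-fold higher number from compound 1 to compound 2 (0.30 log units; within the scatter). For compound 4 the estimate in this assay is 460 nM, expected to lie between 230 nM and 920 nM.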

Compound 4, half-maximal inhibitory concentration: 1650 nM
The estimate for compound 4 lay 3.6-fold (0.55 log units) below the measured number; the whole stated range lies below it.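

In this assay the change from 2-chlorophenyl to 2,4-dichlorophenyl gives a 7.2-fold higher number from compound 3 to compound 4 (0.86 log units; beyond the scatter) and so makes a clearly weaker inhibitor on this core. The same change does not have the same size of effect on the two cores: the same change on two cores in this assay, a 2.0-fold higher number (0.30 log units; within the scatter) from compound 1 to compound 2 and a 7.2-fold higher number (0.86 log units; beyond the scatter) from compound 3 to compound 4, 3.6-fold (0.55 log units) apart, beyond the scatter of two such steps. For the compounds shown here, a step measured on one core was therefore a poor guide to the size of the step on the other, although this rests on only one pair of compounds per core and does not show why the two cores respond differently.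

The two pairs differ from each other both in the side chain that ends in the dimethylamino group and in the core, so the compounds shown cannot say which of these differences goes with the larger step; a compound joining the side chain of compound 3 to the core of compound 1 would separate the two. They also leave open whether the chloro group itself matters or any added group at that place would do the same, which a fluoro, methyl or methoxy group there could test on both cores.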